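Amide aryl swap from compound 3 to compound 4

The source may hold more compounds than are shown below. What is called first, only, known or untested is meant among the compounds shown, and "the series" means these compounds.

Compound 3 `Cc1ccnc(C)c1NC(=O)[C@@H]1CCCN1S(=O)(=O)c1cccc2cccnc12` is measured in an ADME assay on HEp-2 cells (Homo sapiens) for cytotoxicity (a higher number here means that more compound is tolerated, a lower number that less compound is tolerated), only as a limit: in this assay compound 3 gives > 50000 nM. Two other compounds share the core of compound 3. Compound 1 `CCc1ccccc1NC(=O)[C@@H]1CCCN1S(=O)(=O)c1cccc2cccnc12` also sits at a limit, giving > 50000 nM in this assay. Compound 2 `CC(C)c1ccccc1NC(=O)[C@@H]1CCCN1S(=O)(=O)c1cccc2cccnc12` gives a number rather than a limit in this assay, 29900 nM. The step of an at least 1.6-fold lower number from compound 1 to compound 2 (0.22 log units; that floor lies within the scatter) lies within the scatter; the step of an at least 1.6-fold higher number from compound 2 to compound 3 (0.22 log units; that floor lies within the scatter) sets only a floor; the step that the two limits leave unreadable from compound 1 to compound 3 cannot be sized because of the limit of > 50000 nM in this assay, at which 2 of the 3 values shown sit.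

Compound 4 `Cc1cccc(C)c1NC(=O)[C@@H]1CCCN1S(=O)(=O)c1cccc2cccnc12` is not yet measured. Its difference from compound 3 is 2,6-dimethylphenyl in place of 2,4-dimethylpyridin-3-yl on an amide-type nitrogen. For the measured compounds named here, the only measured exchange of the aryl group on the amide-type nitrogen, from compound 2 to compound 3, reached the limit, and compound 1 with a different aryl group sits there too, so little room is seen for a readable change. Compound 4 is therefore expected to stay at or near the limit, the expected step of a number no higher from compound 3 to compound 4 (the limit leaves the size open) being none beyond the scatter. The estimate for compound 4 is 50000 nM, expected between 20000 nM and 120000 nM.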

Compound 4, half-maximal cytotoxic concentration: > 50000 nM
Compound 4: only a limit was reported (the forecaster's own chance of this, stated with the estimate: 65%); the middle value lies on the limit itself.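

Notes on the aryl group on the amide-type nitrogen: in this assay, a ring of carbon only, 2,6-dimethylphenyl, now joins the ring with 1 hetero atom, 2,4-dimethylpyridin-3-yl, at the limit, so the ring nitrogen is not needed for a compound to sit there. The only readable new step is an at least 1.6-fold higher number from compound 2 to compound 4 (0.22 log units; that floor lies within the scatter) and it gives a floor only, so no real difference from 2-isopropylphenyl is shown. The steps to compound 4 from compound 3 and from compound 1 cannot be read because both ends of each sit at the same limit: the limit of > 50000 nM in this assay, at which 3 of the 4 values shown sit.

Going by these compounds, how far compound 1, compound 3 and compound 4 lie past that limit, and any order among them, stays open. Also open, on these data alone, is whether a carboxylic acid or an amine on the aryl ring, or a chain longer than isopropyl, would give a readable value.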